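From Dimethylamino to Dimethoxy on the Shared Core

A few compounds are considered here, and "the series" means these few. Any claim that something is new, unique, unknown or untested is made for them only; others in the source may bear on it.

Of the compounds shown here, two with the shared core have been measured in a physicochemical assay for lipophilicity; a lower number here means a more polar compound, a higher number a more lipophilic compound. For the measured compounds named here, compound 1 `C[C@H]1CC[C@@H]2[C@@H](OC(=O)[C@]23CC(c2ccccc2)=NO3)[C@]2(C)C(=O)C=C[C@@]12O` gives 1.41, and compound 2 `C[C@H]1CC[C@@H]2[C@@H](OC(=O)[C@]23CC(c2ccc(N(C)C)cc2)=NO3)[C@]2(C)C(=O)C=C[C@@]12O` gives 1.51, so compound 2 stands within the scatter of the only other measured compound. Compound 3 `COc1ccc(C2=NO[C@]3(C2)C(=O)O[C@@H]2[C@H]3CC[C@H](C)[C@]3(O)C=CC(=O)[C@@]23C)cc1OC` has not yet been measured. The change from compound 2 is this: 3,4-dimethoxyphenyl in place of 4-(dimethylamino)phenyl on a carbon with a double bond to nitrogen. The exchanged group sits on a carbon with a double bond to nitrogen of a five-membered non-aromatic ring with 1 nitrogen and 1 oxygen.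

Going by the values given here, one measured step bears on this, and it is small: a number 0.10 log units higher from compound 1 to compound 2 (within the scatter), with dimethylamino in place of hydrogen on an aromatic carbon. Among the compounds with values here, no measured step introduces a methoxy group, so the evidence is thin. Within the data shown here, with only that step to compound 2, which gives 1.51, to go on, no step beyond the scatter is expected in this assay. The estimated step is a number 0.11 log units lower from compound 2 to compound 3 (within the scatter). For compound 3 the expected value is 1.4, with an estimated range from 1.1 to 1.7.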

Compound 3, partition coefficient: 1.06
Compound 3: the middle estimate sits 0.34 log units above what was measured, outside the stated range (below it).
By their numbers in this assay, from the lowest: compound 3; then compounds 1 and 2 (each within the scatter of the next).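

For the compounds shown here, until now, the aryl group on a carbon with a double bond to nitrogen of the five-membered non-aromatic ring had shifted the number in this assay by no more than the scatter, and 3,4-dimethoxyphenyl is the first group there to go beyond it. The exchange of 4-(dimethylamino)phenyl for 3,4-dimethoxyphenyl gives a number 0.45 log units lower from compound 2 to compound 3 (beyond the scatter) and the exchange of phenyl for the same group gives a number 0.35 log units lower from compound 1 to compound 3 (beyond the scatter) so compound 3 stands apart from both others, which remain within the scatter of each other. Nothing measured here accounts for this shift.

The compounds shown cannot separate the contributions of the two methoxy groups, so it remains open whether a single methoxy group on the aromatic ring would give a step beyond the scatter or one within it. Also open, from the compounds shown here alone, is where a carboxylic acid, a longer alkoxy chain or a chlorine atom on that aromatic ring would fall, and whether the step seen here would hold with any other change to the shared core.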